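Trifluoro anilino analogue: expected maximal response

The source may report more compounds than this note shows. Statements on the series, on what has been measured and on what is new or still open speak of the compounds shown alone.

Compound 1 `O=C1C(Nc2cccc(F)c2)=CC(=O)c2ncccc21` is the reference point of this series. In a functional assay on the whole organism (aorta) with Rattus norvegicus as the target (a higher number here means a larger maximal response, a lower number a smaller maximal response), compound 1 gives 85%. Compound 2 `O=C1C(Nc2ccc(F)c(F)c2)=CC(=O)c2ncccc21` differs from compound 1 by fluoro in place of hydrogen on an aromatic carbon; the step was a number 7 percentage points higher from compound 1 to compound 2 (within the scatter).

Compound 3 `O=C1C=C(Nc2ccc(F)cc2F)C(=O)c2cnccc21` is built on a different core; the difference between the two cores is not broken down here. In this assay compound 3 gives 96% and compound 2 gives 92%; the numbers for compound 3 and compound 2 lie within the scatter of each other, while the gap from compound 1 to compound 3 lies beyond it.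

Compound 4 `O=C1C=C(Nc2ccc(F)c(F)c2F)C(=O)c2cnccc21` has not yet been measured. It differs from compound 3 by fluoro in place of hydrogen on an aromatic carbon. This is the same kind of change as that from compound 1 to compound 2, not the same one: in compound 2 the entering fluoro sits ortho to a fluoro group and para to a large group, whereas in compound 4 it sits ortho to two fluoro groups and meta to a large group.

Going by the values given here, for compound 4 the step in this assay is expected to be small, a number 1 percentage points higher from compound 3 to compound 4 (within the scatter), because the only measured instance of this kind of change was a number 7 percentage points higher from compound 1 to compound 2 (within the scatter) and compound 3 already gives 96%. Compound 4 is therefore estimated at 97%, with a likely range from 86% to 106%.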

Compound 4, largest response reached (Emax), in percent of the reference or control that the assay uses: 87%
The estimate for compound 4 lay 10 percentage points above the measured number; measured number inside the range.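

In this assay, fluoro in place of hydrogen on an aromatic carbon gives a number 9 percentage points lower from compound 3 to compound 4 (within the scatter). Set beside the earlier step, this change does not carry over with the same result from one core to the other, so the earlier step cannot be transferred as a fixed increment in this series: the same change on two cores in this assay, a number 7 percentage points higher (within the scatter) from compound 1 to compound 2 and a number 9 percentage points lower (within the scatter) from compound 3 to compound 4, 16 percentage points apart, beyond the scatter of two such steps This does not show that the core alone accounts for the gap, as the two pairs also differ in where the fluoro enters, and in compound 4 it sits ortho to two fluoro groups and meta to a large group; each step on its own also lies within the scatter, and one pair per core gives no general rule.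

The compounds shown leave open whether a fluoro entering at the same place on both cores would give matching steps, which would separate the effect of the core from that of the place. They also leave open how groups other than fluoro on the six-membered aromatic ring of carbon, such as chloro, methoxy or an amine, would behave in this assay on either core.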